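Compound 3 to compound 4: pyridin-3-yl replacement

A few compounds are considered here, and "the series" means these few. Any claim that something is new, unique, unknown or untested is made for them only; others in the source may bear on it.

In a functional assay on HeLa cells (Homo sapiens) for cytotoxicity, read by ELISA, with a stated time of 4 days (a higher number here means a weaker inhibitor, a lower number a stronger inhibitor), compound 1 (`Cc1ccccc1-c1cc(-c2ccoc2)cc(-c2ccc(Cl)s2)n1`) gives 19000 nM, compound 2 (`Clc1ccc(-c2cc(-c3ccoc3)cc(-c3ccccc3Cl)n2)s1`) gives 19000 nM and compound 3 (`Clc1ccc(-c2cc(-c3ccoc3)cc(-c3ccc(Cl)s3)n2)cc1`) gives 16500 nM. These three values lie within the scatter of each other, so compound 3 stands level with the other two.

Compound 4 (`Clc1ccc(-c2cc(-c3ccoc3)cc(-c3cccnc3)n2)s1`) carries pyridin-3-yl in place of 4-chlorophenyl on an aromatic carbon next to the ring nitrogen: pyridin-3-yl in place of 4-chlorophenyl on an aromatic carbon.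

Among the measured compounds shown here, three measured steps bear on this place, each exchanging one substituted phenyl group for another: no change at the digits printed from compound 1 to compound 2 (within the scatter), a 1.2-fold lower number from compound 1 to compound 3 (0.06 log units; within the scatter) and a 1.2-fold lower number from compound 2 to compound 3 (0.06 log units; within the scatter). None of them goes beyond the scatter. For the measured compounds named here, no measured compound carries pyridin-3-yl here, so the evidence for this exchange is indirect and the range is kept wide.

On the evidence of a 1.2-fold lower number from compound 2 to compound 3 (0.06 log units; within the scatter), no step beyond the scatter is expected in this assay, in either direction. The estimated step is a 1.1-fold higher number from compound 3 to compound 4 (0.04 log units; within the scatter).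

For compound 4 the estimated value is 18000 nM, with an expected range from 9000 nM to 40000 nM.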

Compound 4, half-maximal inhibitory concentration: 20000 nM
Beside the measured number, compound 4's estimate is 1.1-fold (0.05 log units) below it; the measured number falls inside the stated range.
By their numbers in this assay, from the lowest: compounds 3, 1, 2 and 4 (each within the scatter of the next).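

In this assay, among the compounds shown here, pyridin-3-yl is the only group at this place with a hetero atom in its ring and a hydrogen-bond acceptor, yet the number stays level with all three phenyl-bearing compounds (a 1.2-fold higher number from compound 3 to compound 4 (0.08 log units; within the scatter); a 1.1-fold higher number from compound 2 to compound 4 (0.02 log units; within the scatter); a 1.1-fold higher number from compound 1 to compound 4 (0.02 log units; within the scatter)). The tolerance seen so far among substituted phenyl groups therefore extends, across these four compounds, to a six-membered aromatic ring with a ring nitrogen and no chlorine or methyl group. No measurement on these compounds offers an explanation for this flat result.

Still open, from the compounds shown here alone, is whether any group at this place can move the number beyond the scatter, for instance an amine, a carboxylic acid or a longer alkyl chain in place of the aromatic ring. Also open, going by these compounds, is whether the same flatness holds once the furan-3-yl or 5-chlorothiophen-2-yl group is exchanged.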